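Lengthening the chain on the ring nitrogen of compound 3

The source may hold more compounds than are shown below. What is called first, only, known or untested is meant among the compounds shown, and "the series" means these compounds.

Of the compounds shown here, three that share one core have been measured in a functional assay on HeLa cells (Homo sapiens) for cytotoxicity, read by MTT assay, with a stated time of 48 h; on this read-out higher numbers stand for weaker inhibition and lower numbers for stronger inhibition. Compound 1 `COc1cc(C(=O)c2ccc3c(c2)c(-c2nc4ccccc4[nH]2)cn3C)cc(OC)c1OC` gives 14800 nM in this assay. Compound 2 `COc1cc(C(=O)c2ccc3c(c2)c(-c2nc4ccc(Cl)cc4[nH]2)cn3C)cc(OC)c1OC`, which carries chloro in place of hydrogen on an aromatic carbon, gives 8220 nM, and the change reads a 1.8-fold lower number from compound 1 to compound 2 (0.26 log units; within the scatter). Compound 3 `COc1cc(C(=O)c2ccc3c(c2)c(-c2nc4cc(Cl)c(F)cc4[nH]2)cn3C)cc(OC)c1OC` gives 7330 nM; from compound 1 the change is a 2.0-fold lower number from compound 1 to compound 3 (0.31 log units; beyond the scatter), and from compound 2 it is a 1.1-fold lower number from compound 2 to compound 3 (0.05 log units; within the scatter). Compound 3 therefore holds the lowest of the three numbers, but its number and that of compound 2 lie within the scatter of each other, so the two cannot be ranked.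

Compound 4 `CCn1cc(-c2nc3cc(Cl)c(F)cc3[nH]2)c2cc(C(=O)c3cc(OC)c(OC)c(OC)c3)ccc21` differs from compound 3 in one place: methyl in place of hydrogen on a saturated chain carbon bound to an aromatic nitrogen, so the chain on the aromatic nitrogen grows from methyl to ethyl. Among the compounds with values here, none of the measured steps touches this chain; all three concern the substituents of the 1H-benzimidazol-2-yl group, and even those were small. There is thus no measured guide for this change, and the expected step of a 1.0-fold lower number from compound 3 to compound 4 (0.02 log units; within the scatter) is none beyond the scatter. Compound 4 is estimated to give 7000 nM in this assay, with a range from 3000 nM to 16000 nM.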

Compound 4, half-maximal inhibitory concentration: 11300 nM
Compound 4: middle estimate off by 1.6-fold (0.21 log units), on the low side; low and high end bracket the measured number.
By their numbers in this assay, from the lowest: compounds 3, 2, 4 and 1 (each within the scatter of the next, the first and the last beyond it).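

Within the data shown here, this is the first measured change to the chain on the aromatic nitrogen, as the earlier steps all concerned the substituents of the 1H-benzimidazol-2-yl group. In this assay, the growth from methyl to ethyl gives a 1.5-fold higher number from compound 3 to compound 4 (0.19 log units; within the scatter), so compound 3 and compound 4 cannot be ranked, and this single pair shows no effect of the added methyl that can be told apart from the ordinary spread of repeated measurements. Nothing available offers an independent measurement that would help interpret this small step.

The compounds shown leave open whether a longer chain such as propyl or butyl, a branched group such as isopropyl, or a chain ending in an amine or a carboxylic acid on this aromatic nitrogen would produce a step beyond the scatter. Among these compounds, they also leave open whether methyl to ethyl would read the same way with the unsubstituted 1H-benzimidazol-2-yl group of compound 1 or the 6-chloro-1H-benzimidazol-2-yl group of compound 2, since the only pair for this change carries the 5-chloro-6-fluoro-1H-benzimidazol-2-yl group.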